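This account rests on a few compounds, and the source may have more. Where it says the series, first, only, none or still open, it means among the compounds named here.

Measured in an ADME assay on HepG2 cells (Homo sapiens) for cytotoxicity, read by luminescence, with a stated time of 72 h (on this read-out lower numbers stand for an effect already at smaller amounts and higher numbers for an effect only at larger amounts of compound), every entry being a limit and not a number:
- compound 1 `CCOC(=O)c1c(-c2ccccc2)[nH]c2cc(OC)ccc2c1=O` gives > 21500 nM
- compound 2 `CCOC(=O)c1c(-c2cccc(-c3ccccc3)c2)[nH]c2cc(OC)ccc2c1=O` gives > 21500 nM
- compound 3 `CCOC(=O)c1c(-c2cccc(OCc3ccccc3)c2)[nH]c2cc(OC)ccc2c1=O` gives > 21500 nM

Compound 3 gives > 21500 nM in this assay, and this is a limit, so it has no number of its own to start from.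

The next compound is compound 4 `CCOC(=O)c1c(-c2cccc(Oc3ccccc3)c2)[nH]c2cc(OC)ccc2c1=O`, with phenyl in place of benzyl on an oxygen on an aromatic ring, that is, benzyloxy to phenoxy (phenyl in place of benzyl on an oxygen on an aromatic ring).

Among the compounds with values here, three measured steps bear on this change. The closest is a step that the two limits leave unreadable from compound 2 to compound 3, which swaps benzyloxy in for phenyl on an aromatic carbon. The other two are a step that the two limits leave unreadable from compound 1 to compound 3 and a step that the two limits leave unreadable from compound 1 to compound 2, each replacing hydrogen on an aromatic carbon. None of them has a readable size, so they give no step size to carry over and no direction.

Because the limit of > 21500 nM in this assay, at which 3 of the 3 values shown sit, holds for compound 1, compound 2 and compound 3 alike, compound 4 is expected to report a limit as well, with no step beyond the scatter foreseen. The expected step is a step that the limit leaves unreadable from compound 3 to compound 4, with neither direction favoured. For compound 4 the estimated value is 30000 nM, with an expected range from 20000 nM to 50000 nM, should a number be reported at all.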

Compound 4, half-maximal effective concentration: > 21500 nM
Compound 4 gave a limit, no number (the forecaster's own chance of this, stated with the estimate: 85%); the middle value does not contradict the limit.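

With compound 4 also reported as a limit in this assay, no step among compound 1, compound 2, compound 3 and compound 4 can be read, as all four entries are limits: the limit of > 21500 nM in this assay, at which 4 of the 4 values shown sit.

The compounds shown leave open whether any of them has a numerical half-maximal effective concentration in this assay, and whether their values differ at all.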